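Cyclopropylmethyl in Place of Methyl on the Shared Core

The compounds below may be only part of what the source reports. "The series", "measured", "known", "first", "only" and "open" are said of these compounds alone.

Of the compounds shown here, two built on a shared core have been measured in an in vitro assay on U2OS cells for agonist activity at neurotensin receptor type 2 (Homo sapiens), read by reporter gene assay and beta-arrestin recruitment; on this read-out lower numbers stand for an effect already at smaller amounts and higher numbers for an effect only at larger amounts of compound. Compound 1 `COc1cc2nc(C3CCC3)nc(N3CCN(c4ccccc4Cl)CC3)c2cc1OC` is one of them. In this assay compound 1 gives only a limit, > 80000 nM. Compound 2 `COc1cc2nc(C)nc(N3CCN(c4ccccc4OC)CC3)c2cc1OC` is the other. In this assay compound 2 likewise gives only a limit, > 80000 nM. Where compound 2 stands among the numbers shown is thus a limit rather than a number, and because both values sit at the limit described by the limit of > 80000 nM in this assay, at which 2 of the 2 values shown sit, no order between compound 1 and compound 2 can be read from them.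

Compound 3 `COc1cc2nc(CC3CC3)nc(N3CCN(c4ccccc4OC)CC3)c2cc1OC` differs from compound 2 in one place: cyclopropyl in place of hydrogen on a saturated chain carbon bound to an aromatic carbon. Going by the values given here, no measured pair with a single difference is available to calibrate this change. Compound 3 is therefore expected to remain at a limit, and the step from compound 2 to compound 3 is estimated as a number no higher from compound 2 to compound 3 (the limit leaves the size open), with no movement beyond the scatter expected. Compound 3 is estimated at 80000 nM, within a range from 20000 nM to 300000 nM.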

Compound 3, half-maximal effective concentration: > 80000 nM
Compound 3 gave a limit, no number; the forecaster's own chance of this, stated with the estimate: 80%; the middle value sits exactly at the limit.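

No step can be read from compound 2 to compound 3 in this assay because both compounds sit at the same limit: the limit of > 80000 nM in this assay, at which 3 of the 3 values shown sit.

The compounds shown leave open whether methyl to cyclopropylmethyl changes the half-maximal effective concentration at all, and what number any compound on the shared core would give.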